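Swapping a substituted phenoxy for plain phenyl on the core

A few compounds are considered here, and "the series" means these few. Any claim that something is new, unique, unknown or untested is made for them only; others in the source may bear on it.

Measured compounds so far:
compound 1, `CCCCCCCCc1ccc(OC(C)C(=O)Cn2nnc(-c3ccc(Cl)cc3)n2)cc1`, 35 nM
compound 2, `CC(Oc1ccc(Oc2ccc(F)cc2)cc1)C(=O)Cn1nnc(-c2ccc(Cl)cc2)n1`, 42 nM
compound 3, `CC(Oc1ccc(Oc2ccc(C(F)(F)F)cc2)cc1)C(=O)Cn1nnc(-c2ccc(Cl)cc2)n1`, 300 nM

In an assay on microsomes from brain for inhibition of Fatty-acid amide hydrolase 1 (Rattus norvegicus), read by fluorescence and HPLC, with a stated time of 60 min (a lower number here means a stronger inhibitor, a higher number a weaker inhibitor), compound 3 has the highest number of the three, so it is the weakest inhibitor shown; its nearest neighbour is compound 2, and its furthest is compound 1. Compound 4, `CC(Oc1ccc(-c2ccccc2)cc1)C(=O)Cn1nnc(-c2ccc(Cl)cc2)n1`, has not yet been measured. It differs from compound 3 by phenyl in place of 4-(trifluoromethyl)phenoxy on an aromatic carbon.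

For the measured compounds named here, no measured step tests phenyl at this position. Going by the values given here, the steps that bear on it show what happens when the group there is changed: a 1.2-fold higher number from compound 1 to compound 2 (0.08 log units; within the scatter), an 8.6-fold higher number from compound 1 to compound 3 (0.93 log units; beyond the scatter) and a 7.1-fold higher number from compound 2 to compound 3 (0.85 log units; beyond the scatter). Two of the three groups tried, in compound 1 and compound 2, give low numbers, and only compound 3 falls behind, so removing the trifluoromethyl-bearing ring is expected to bring the number back toward those of compound 1 and compound 2, though phenyl has not been tried. Compound 4 is therefore estimated at 70 nM, with a range from 20 nM to 250 nM, which means an expected step of a 4.3-fold lower number from compound 3 to compound 4 (0.63 log units; beyond the scatter).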

Compound 4, half-maximal inhibitory concentration in the Fatty-acid amide hydrolase 1 assay: 25 nM
Compound 4: middle estimate off by 2.8-fold (0.45 log units), on the high side, within the range that was stated.
By their numbers in the Fatty-acid amide hydrolase 1 assay, from the lowest: compounds 4, 1 and 2 (each within the scatter of the next); then compound 3.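

In the Fatty-acid amide hydrolase 1 assay, this position accepts a phenyl attached directly to the ring, and the change from 4-(trifluoromethyl)phenoxy gives a 12-fold lower number from compound 3 to compound 4 (1.08 log units; beyond the scatter). In the Fatty-acid amide hydrolase 1 assay, phenyl also holds level with the other two groups, with a 1.7-fold lower number from compound 2 to compound 4 (0.23 log units; within the scatter) and a 1.4-fold lower number from compound 1 to compound 4 (0.15 log units; within the scatter), so octyl, 4-fluorophenoxy and phenyl cannot be told apart here, and compound 3 alone stands apart. In a physicochemical assay for lipophilicity, read by HPLC, tested at 5 mM (on this read-out lower numbers stand for lower lipophilicity and higher numbers for higher lipophilicity), compound 3 gives 7 and compound 4 gives 6.1. In the physicochemical assay, lipophilicity falls along with the gain in this one pair, but a single pair cannot show that the fall causes the gain: the measured partition coefficient of compound 3, 7, and of compound 4, 6.1, a number 0.90 log units lower (beyond the scatter).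

As far as these compounds go, it remains open whether a trifluoromethyl group on the phenyl of compound 4 would cost as much as it does on the phenoxy. From the compounds shown here alone, how a carboxylic acid or an amine on that phenyl would behave in either assay also remains open.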